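This account rests on a few compounds, and the source may have more. Where it says the series, first, only, none or still open, it means among the compounds named here.

Measured compounds in a functional assay on IGROV-1 cells (Homo sapiens) for inhibition, read by sulforhodamine B assay, with a stated time of 48 h; on this read-out lower numbers stand for stronger inhibition of growth and higher numbers for weaker inhibition of growth:

Compound 1 `Nc1cc(N)c2nc(-c3ccccc3)c(Sc3ccc(F)cc3)nc2c1` gives < 100000 nM, which is a limit of the assay rather than a number.
Compound 2 `COc1cc(CNc2nc3cc(N)cc(N)c3nc2-c2ccccc2)cc(OC)c1OC` gives < 50200 nM, which is also a limit of the assay rather than a number.

On the numbers shown, compound 1 stands only at a limit: the result for compound 1 is the one described by the limit of < 100000 nM in this assay, at which 1 of the 2 values shown sits, so its true growth-inhibiting concentration is not fixed by these data, and the value for compound 2 is likewise a limit, as described by the limit of < 50200 nM in this assay, at which 1 of the 2 values shown sits. Nothing can be said about the order of compound 1 and compound 2 from two limits.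

Compound 3 `Nc1cc(N)c2nc(-c3ccccc3)c(Sc3ccc(Cl)c(Cl)c3)nc2c1` has not been measured in this assay. It differs from compound 1 by 3,4-dichlorophenyl in place of 4-fluorophenyl on a sulfur. For the measured compounds named here, no step between measured compounds exists to guide this change. Because compound 1 shows only < 100000 nM, the starting point itself is open, and the step from compound 1 to compound 3 is expected to be modest, a step that the limit leaves unreadable from compound 1 to compound 3, with no direction established beyond the scatter. Compound 3 is therefore estimated at 30000 nM, within a range from 5000 nM to 100000 nM.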

Compound 3, concentration for total growth inhibition: 27500 nM
Compound 3: the middle estimate sits 1.1-fold (0.04 log units) above what was measured; the range from low to high includes it.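

No step can be read from compound 1 to compound 3, because the result for compound 1 is a limit and not a number: the limit of < 100000 nM in this assay, at which 1 of the 3 values shown sits.

The compounds shown leave open whether 3,4-dichlorophenyl in place of 4-fluorophenyl on a sulfur changes the result in this assay at all, and in which direction.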